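From anilino to methylamino on the shared core

The compounds below may be only part of what the source reports. "The series", "measured", "known", "first", "only" and "open" are said of these compounds alone.

Values measured in a functional assay on SK-MEL-28 cells (Homo sapiens) for cytotoxicity, read by MTT assay, with a stated time of 3 days (on this read-out higher numbers stand for weaker inhibition and lower numbers for stronger inhibition), are as follows.
- compound 1 `N#Cc1c(Cl)nc(SCc2nc3ccccc3[nH]2)nc1-c1ccccc1` gives 3.28 nM
- compound 2 `N#Cc1c(Nc2ccccc2)nc(SCc2nc3ccccc3[nH]2)nc1-c1ccccc1` gives 8.9 nM

Compound 2 (8.9 nM) holds the higher of the two numbers. Compound 3 `CNc1nc(SCc2nc3ccccc3[nH]2)nc(-c2ccccc2)c1C#N` differs from it by methyl in place of phenyl on a nitrogen on an aromatic ring. Going by the values given here, the only measured step bearing on this is the modest 2.7-fold higher number from compound 1 to compound 2 (0.43 log units; beyond the scatter) for anilino in place of chloro on an aromatic carbon. Among the compounds with values here, no measured compound carries methylamino, so only a modest step towards lower numbers is expected in this assay and its direction remains uncertain. The estimated step (a 1.5-fold lower number from compound 2 to compound 3 (0.17 log units; within the scatter)) stays of that order. For compound 3 the expected value is 6 nM within an estimated range of 1.5 nM to 25 nM for this measurement.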

Compound 3, half-maximal inhibitory concentration: 2.87 nM
Beside the measured number, compound 3's estimate is 2.1-fold (0.32 log units) above it; the measured number falls inside the stated range.
By their numbers in this assay, from the lowest: compounds 3 and 1 (each within the scatter of the next); then compound 2.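

In this assay, swapping phenyl for methyl on the nitrogen reverses the loss seen with anilino (a 3.1-fold lower number from compound 2 to compound 3 (0.49 log units; beyond the scatter)), so an amino group at this position does not by itself raise the number. Methylamino in place of chloro gives a 1.1-fold lower number from compound 1 to compound 3 (0.06 log units; within the scatter), and of the two amino groups shown, only anilino stands apart from chloro. No evidence is available on what lies behind this difference between methyl and phenyl.

Still open, as far as these compounds go, is where an ethylamino or benzylamino group, or a ring amine such as morpholine, would fall at this position.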